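The compounds below may be only part of what the source reports. "The series", "measured", "known", "first", "only" and "open" are said of these compounds alone.

Measured so far:
Compound 1, `COc1cc(O)c(C(=O)/C=C/c2ccc(OC)c(OCc3cn(-c4ccccc4Cl)nn3)c2)c(OC)c1`: in an ADME assay on Huh-7 cells (Homo sapiens) for cytotoxicity, read by MTT assay, with a stated time of 72 h (on this read-out higher numbers stand for lower toxicity in this test and lower numbers for higher toxicity in this test), compound 1 gives > 100 ug/mL, which is a limit of the assay and not a number.
Compound 2, `COc1cc(O)c(C(=O)/C=C/c2ccc(OCc3cn(-c4ccc(F)cc4Cl)nn3)c(OCc3cn(-c4ccc(F)cc4Cl)nn3)c2)c(OC)c1`: in this assay compound 2 gives > 100 ug/mL, again a limit of the assay rather than a number.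

For the measured compounds named here, compound 1 therefore stands at the limit of this assay, with no number of its own, and the one other value known sits at the same limit, so nothing measured here can be ranked. The unmeasured compound 3, `COc1cc(O)c(C(=O)/C=C/c2ccc(OC)c(OCc3cn(-c4ccc(F)cc4F)nn3)c2)c(OC)c1`, differs from compound 1 by 2,4-difluorophenyl in place of 2-chlorophenyl on an aromatic nitrogen. Going by the values given here, no two measured compounds differ in a single place, so no measured step is available to guide this change. In this assay the step that the limit leaves unreadable from compound 1 to compound 3 is expected to be none beyond the scatter, because of the limit of > 100 ug/mL in this assay, at which 2 of the 2 values shown sit. Compound 3 is accordingly estimated at 150 ug/mL, with a range from 60 ug/mL to 400 ug/mL, and the assay is expected most likely to return only its limit once more.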

Compound 3, half-maximal cytotoxic concentration: > 100 ug/mL
Compound 3: no number, only a limit; the forecaster's own chance of this, stated with the estimate: 85%; the middle value does not contradict the limit.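

In this assay compound 3 gives > 100 ug/mL, a limit of the assay and not a number. For the compounds shown here, compound 1 also stands at a limit, so no step between compound 1 and compound 3 can be read. The compounds shown leave open whether 2,4-difluorophenyl in place of 2-chlorophenyl changes toxicity in this test at all.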